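The compounds below may be only part of what the source reports. "The series", "measured", "known", "first", "only" and "open" are said of these compounds alone.

Compound 1 `CCS(=O)(=O)Nc1ccc(CNC(=O)c2ccc(C(C)(C)C)cc2)c(Cl)c1` and compound 2 `CC(C)S(=O)(=O)Nc1ccc(CNC(=O)c2ccc(C(C)(C)C)cc2)c(Cl)c1` share one core. In an assay on HeLa cells for agonist activity at Bile acid receptor (Homo sapiens), read by a luciferase reporter, with a stated time of 24 h (a higher number here means that more compound is needed for the effect, a lower number that less compound is needed), compound 1 gives 500 nM and compound 2 gives 420 nM. The change between them, (methyl in place of hydrogen on a saturated chain carbon bound to a saturated chain carbon and a sulfonyl sulfur), produces a 1.2-fold lower number from compound 1 to compound 2 (0.08 log units; within the scatter). Compound 3 `CCOc1ccc(C(=O)NCc2ccc(NS(C)(=O)=O)cc2Cl)cc1` carries a different core; the difference between the two cores is not broken down here. In this assay compound 3 gives 2200 nM, the highest number of the three. Compound 4 `CC(C)Oc1ccc(C(=O)NCc2ccc(NS(C)(=O)=O)cc2Cl)cc1` is not yet measured and differs from compound 3 by methyl in place of hydrogen on a saturated chain carbon bound to an oxygen on an aromatic ring and a saturated chain carbon. This is the same kind of change as that made from compound 1 to compound 2, not the same: there the carbon is bound to a saturated chain carbon and a sulfonyl sulfur, here to an oxygen on an aromatic ring and a saturated chain carbon. Because a 1.2-fold lower number from compound 1 to compound 2 (0.08 log units; within the scatter) lies within the scatter, the step expected in this assay is a 1.2-fold lower number from compound 3 to compound 4 (0.06 log units; within the scatter), again a small one. Compound 4 is accordingly estimated at 1900 nM, with a range from 900 nM to 4000 nM.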

Compound 4, half-maximal effective concentration: 400 nM
Estimate against measurement, compound 4: 4.8-fold (0.68 log units) above; measured number outside the range, below it.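

In this assay, going from ethoxy to isopropoxy gives a 5.5-fold lower number from compound 3 to compound 4 (0.74 log units; beyond the scatter), so on the core of compound 3 this added methyl produces a real step. Across the two cores shown, the change does not carry over at one size: the same change on two cores in this assay, a 1.2-fold lower number (0.08 log units; within the scatter) from compound 1 to compound 2 and a 5.5-fold lower number (0.74 log units; beyond the scatter) from compound 3 to compound 4, 4.6-fold (0.66 log units) apart, beyond the scatter of two such steps. The two steps also sit on different carbons, one bound to a sulfonyl sulfur and the other to an oxygen on an aromatic ring, so these compounds do not separate the effect of the core from that of the place, and two pairs give no general rule.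

On these data alone, whether the ethoxy to isopropoxy step holds on the core of compound 1 remains open. So does how a longer chain or an amine at this carbon would read.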